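The source may hold more compounds than are shown below. What is called first, only, known or untested is meant among the compounds shown, and "the series" means these compounds.

Two compounds of this series have so far been examined in an ADME assay on L02 cells (Homo sapiens) for cytotoxicity, read by MTT assay, with a stated time of 24 h; on this read-out lower numbers stand for higher toxicity in this test and higher numbers for lower toxicity in this test. Compound 1 `O=c1[nH]cc(S(=O)(=O)Nc2ccccc2-c2cn(-c3ccc(F)cc3)nn2)c(=O)[nH]1` was recorded in this assay as "not toxic" (no number reported), with no number attached to that entry. Compound 2 `Cc1cccc(-n2cc(-c3cccc(NS(=O)(=O)c4c[nH]c(=O)[nH]c4=O)c3)nn2)c1` gives in this assay 28300 nM, and this is the only figure reported in the test; the entry for compound 1 stands beside it without a number, so compound 2 cannot be placed above or below anything. Compound 3 `O=c1[nH]cc(S(=O)(=O)Nc2cccc(-c3cn(-c4ccc(F)cc4)nn3)c2)c(=O)[nH]1` has not yet been tested. It differs from compound 2 in one place: 4-fluorophenyl in place of 3-methylphenyl on an aromatic nitrogen. Compound 3 thus carries the same 4-fluorophenyl group on an aromatic nitrogen that compound 1 carries. Among the measured compounds shown here, no measured pair in this set shows what exchanging a 3-methylphenyl for a 4-fluorophenyl does to the half-maximal cytotoxic concentration, so no direction can be read from the data. Compound 1, which shares that group, was reported as not toxic. The step is therefore expected to be small, a 1.4-fold higher number from compound 2 to compound 3 (0.15 log units; within the scatter), and not beyond the usual scatter, if anything tending toward lower toxicity. Compound 3 is accordingly expected to give about 40000 nM, within a range from 15000 nM to 120000 nM, with a real chance that only a limit is reported.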

Compound 3, half-maximal cytotoxic concentration: "not toxic" (no number reported)
The entry for compound 3 holds no number; the estimate stays without a comparison.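

In this assay, among the compounds shown here, compound 3 is entered as "not toxic" (no number reported) without a figure, while compound 2 gives 28300 nM and so no step between compound 2 and compound 3 can be read. Left open is whether exchanging 3-methylphenyl for 4-fluorophenyl shifts the half-maximal cytotoxic concentration at all. No available evidence bears on this result.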